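A few compounds are considered here, and "the series" means these few. Any claim that something is new, unique, unknown or untested is made for them only; others in the source may bear on it.

Three members of the series have so far been run in a functional assay on HCT-15 cells (Homo sapiens) for cytotoxicity, read by CCK-8 assay; a lower number here means a stronger inhibitor, a higher number a weaker inhibitor. Compound 1 `Oc1ccc(-c2cc(-c3cccs3)cc(-c3ccccc3O)n2)cc1` gives only a limit there, > 50000 nM. Compound 2 `Oc1ccccc1-c1cc(-c2ccsc2)cc(-c2ccccc2O)n1` likewise gives a limit, > 50000 nM. Compound 3 `Oc1ccc(-c2cc(-c3ccsc3)cc(-c3ccccc3O)n2)cc1` stands at the same limit, > 50000 nM. Because all three sit at the limit of > 50000 nM in this assay, at which 3 of the 3 values shown sit, neither a step that the two limits leave unreadable from compound 1 to compound 3 nor a step that the two limits leave unreadable from compound 2 to compound 3 can be read in size or direction. Compound 4 `Oc1ccc(-c2cc(-c3ccsc3)cc(-c3ccc(O)cc3)n2)cc1` differs from compound 3 by 4-hydroxyphenyl in place of 2-hydroxyphenyl on an aromatic carbon. For the measured compounds named here, the one measured step of the same kind, a step that the two limits leave unreadable from compound 2 to compound 3, was unreadable, so the record gives no size to carry over. The expected change in this assay is a step that the limit leaves unreadable from compound 3 to compound 4, nothing beyond the scatter. Compound 4 is therefore expected to remain at the limit, estimated at 80000 nM with a range from 30000 nM to 300000 nM.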

Compound 4, half-maximal inhibitory concentration: 1040 nM
The estimate for compound 4 lay 77-fold (1.89 log units) above the measured number; measured number outside the range, below it.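

In this assay, for the compounds shown here, an at least 48-fold lower number from compound 3 to compound 4 (1.68 log units; beyond the scatter), so the aromatic carbon next to the ring nitrogen does respond to this change, which the earlier steps could not show because they cannot be read. The swap moves only the hydroxyl within the phenyl group, with the same atoms and counts on both sides. Compound 4 is the only one shown that lacks 2-hydroxyphenyl and the only one with a readable number, the others sitting at a limit: the limit of > 50000 nM in this assay, at which 3 of the 4 values shown sit.

From the compounds shown here alone, whether thiophen-2-yl would give a similar number alongside two 4-hydroxyphenyl groups remains open. So does the effect of an amine or a carboxylic acid in place of the hydroxyl.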